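The compounds below may be only part of what the source reports. "The series", "measured", "known", "first", "only" and "open" are said of these compounds alone.

Within the data shown here, compound 2 `Cc1ccc(/C=C/C=N/NC(=O)CN2C(=O)N(c3ccc(Cl)cc3)C(N(O)C(=O)Nc3ccc(Cl)cc3)C2(C)C)o1` was tested in an ADME assay on liver (Mus musculus) for metabolic stability, read by LC-MS, using microsomes and NADPH, tested at 1 uM (a lower number here means that the compound disappears faster, a higher number that the compound lasts longer), and gave 3.3 h, the higher of the two numbers available so far. Its only measured neighbour is compound 1 `COCCOc1ccc(N2C(=O)N(CC(=O)N/N=C/C=C/c3ccc(C)o3)C(C)(C)C2N(O)C(=O)Nc2ccc(Cl)cc2)cc1`, which in this assay gave 2.32 h; the two differ by a 1.4-fold higher number from compound 1 to compound 2 (0.15 log units; within the scatter), so on the numbers shown compound 2 and compound 1 cannot be told apart.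

Compound 3 `COCCOc1ccc(NC(=O)N(O)C2N(c3ccc(Cl)cc3)C(=O)N(CC(=O)N/N=C/C=C/c3ccc(C)o3)C2(C)C)cc1` is the unmeasured compound. It arises from compound 2 by 2-methoxyethoxy in place of chloro on an aromatic carbon. Among the measured compounds shown here, the only measured step that bears on it is the one from compound 1 to compound 2, where the same pair of groups was swapped in the opposite sense, though on the other six-membered aromatic ring of the shared core, and that step was a 1.4-fold higher number from compound 1 to compound 2 (0.15 log units; within the scatter), within the scatter. Nothing beyond this single step is known about the exchange.

The step from compound 2 to compound 3 is therefore expected to be small, a 1.3-fold lower number from compound 2 to compound 3 (0.12 log units; within the scatter), with no clear direction beyond the scatter. Compound 3 is expected to give about 2.5 h in this assay, with a likely range from 1.3 h to 4.8 h.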

Compound 3, half-life: 1.75 h
The estimate for compound 3 lay 1.4-fold (0.15 log units) above the measured number; low and high end bracket the measured number.
By their numbers in this assay, from the lowest: compounds 3, 1 and 2 (each within the scatter of the next).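

In this assay, turning the (4-chlorophenyl)amino group into (4-(2-methoxyethoxy)phenyl)amino gives a 1.9-fold lower number from compound 2 to compound 3 (0.28 log units; within the scatter), so at this position a chain of 5 heavy atoms can replace a single chlorine with no change that stands clear of the scatter. The earlier compounds shown here showed this only for the other aromatic ring of the shared core, with a 1.4-fold higher number from compound 1 to compound 2 (0.15 log units; within the scatter), so the exchange has now been read on both rings, and neither step separates the two compounds involved. Nothing measured here explains these results or shows how the compounds are broken down in the microsomes.

The compounds shown leave open whether a group of a different kind at this position, such as an amine or a carboxylic acid, would move the half-life beyond the scatter. They also leave open what 2-methoxyethoxy on both rings at once would do, since each step shown changes only one ring and a single pair of compounds cannot say whether the two exchanges would add up.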